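Methoxy for chloro: from compound 2 to compound 4

The compounds below may be only part of what the source reports. "The series", "measured", "known", "first", "only" and "open" are said of these compounds alone.

For the measured compounds named here, in an assay on isolated protein for inhibition of Amine oxidase [flavin-containing] A (Homo sapiens), read by fluorescence and spectrophotometry, with a stated time of 20 min (a higher number here means a weaker inhibitor, a lower number a stronger inhibitor), compound 2 `O=C1/C(=C/c2cccc(Cl)c2)Cc2cc(O)ccc21` gives 157 nM, the lowest of the three numbers so far. Compound 3 `O=C1/C(=C/c2ccc(Cl)c(Cl)c2)Cc2cc(O)ccc21` gives 235 nM in this assay. The step of a 1.5-fold higher number from compound 2 to compound 3 (0.18 log units; within the scatter) stays within the scatter. Compound 1 `O=C1/C(=C/c2ccc(F)cc2)Cc2cc(O)ccc21` gives 679 nM, beyond the scatter from compound 2. Compound 4 `COc1cccc(/C=C2\Cc3cc(O)ccc3C2=O)c1` is not yet measured; it differs from compound 2 by methoxy in place of chloro on an aromatic carbon. Going by the values given here, no measured step swaps chloro for methoxy; the one single-point step adds a chloro and is small. Compounds 1 and 2 differ only in the halogen and its placement, and offer no guide for methoxy. In this assay a modest weakening is expected for compound 4, a 2.0-fold higher number from compound 2 to compound 4 (0.31 log units; beyond the scatter), with wide uncertainty. Compound 4 is estimated at 320 nM, range 100 nM to 1000 nM.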

Compound 4, half-maximal inhibitory concentration: 1190 nM
For compound 4 the middle estimate is 3.7-fold (0.57 log units) below the measured one; the whole stated range lies below it.
By their numbers in this assay, from the lowest: compounds 2 and 3 (each within the scatter of the next); then compounds 1 and 4 (each within the scatter of the next).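

In this assay, methoxy in place of chloro on this aromatic carbon, meta to a large group, gives a clear loss, with a 7.6-fold higher number from compound 2 to compound 4 (0.88 log units; beyond the scatter). The only earlier single-place step, with a 1.5-fold higher number from compound 2 to compound 3 (0.18 log units; within the scatter), stayed within the scatter, so this is the first single-place change in the series shown to move the number beyond it. Nothing available bears on the reason for this loss.

As far as these compounds go, whether a methyl, an amine or a nitrile at this place would read nearer compound 2 or compound 4 stays open. So does whether methoxy costs as much elsewhere on this ring.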